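The source may report more compounds than this note shows. Statements on the series, on what has been measured and on what is new or still open speak of the compounds shown alone.

Compound 1 `O=C(CN1CCN(C(=O)c2ccc(Br)cc2)CC1)N1CCN(CCCc2c[nH]c3ccccc23)CC1` and compound 2 `O=C(CN1CCN(C(=O)c2ccc(F)cc2)CC1)N1CCN(CCCc2c[nH]c3ccccc23)CC1` share one core, while compound 3 `O=C(CN1CCN(C(=O)c2cccc(Br)c2)CC1)N1CCN(CCCc2c[nH]c3ccc(F)cc23)CC1` and the not yet measured compound 4 `O=C(CN1CCN(C(=O)c2cccc(F)c2)CC1)N1CCN(CCCc2c[nH]c3ccc(F)cc23)CC1` share another; the difference between the two cores is not broken down here. In an ADME assay on SH-SY5Y cells (Homo sapiens) for cytotoxicity, read by MTT assay, with a stated time of 72 h (on this read-out higher numbers stand for weaker inhibition and lower numbers for stronger inhibition), compound 1 gives 59300 nM and compound 2 gives 188000 nM. Between those two lies a single change, (fluoro in place of bromo on an aromatic carbon), and it made a 3.2-fold higher number from compound 1 to compound 2 (0.50 log units; beyond the scatter). In this assay compound 3 gives 71600 nM. The change from compound 3 to compound 4 is fluoro in place of bromo on an aromatic carbon. It is the same kind of change as the first, though not the same: in the first pair the group sits para to a large group, in the second pair meta to a large group. Among the compounds with values here, compound 4 is expected to show a step of about a 2.8-fold higher number from compound 3 to compound 4 (0.45 log units; beyond the scatter), because the one measured example made a 3.2-fold higher number from compound 1 to compound 2 (0.50 log units; beyond the scatter) and because compound 3 stands at 71600 nM. Within the data shown here, with only one earlier example, and that on a different core and at a different place, the expectation is loose. Compound 4 is therefore estimated at 200000 nM, most likely between 90000 nM and 450000 nM.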

Compound 4, half-maximal inhibitory concentration: 169000 nM
Compound 4: middle estimate off by 1.2-fold (0.07 log units), on the high side, and the stated range covers the measured number.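

Swapping bromo for fluoro made a 2.4-fold higher number from compound 3 to compound 4 (0.37 log units; beyond the scatter) in this assay, so on the core of compound 3 the number rose, meaning weaker inhibition, just as it did on the core of compound 1. Set side by side, the two steps cannot be told apart, so this change carried over from one core to the other with much the same size: the same change on two cores in this assay, a 3.2-fold higher number (0.50 log units; beyond the scatter) from compound 1 to compound 2 and a 2.4-fold higher number (0.37 log units; beyond the scatter) from compound 3 to compound 4, 1.3-fold (0.13 log units) apart, within the scatter of two such steps. Within the data shown here, still, this rests on only two pairs, whose cores differ and whose swapped groups sit at different places on the ring, so it does not show what either difference does alone, why the number rises, or whether the step would hold on a further core.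

The compounds shown leave open whether a chloro group, a methoxy group or an amine in the place of the halogen would fit the same trend. Also open, as far as these compounds go, is whether the step would keep its size if the ring carried the swapped group at another place.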